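The compounds below may be only part of what the source reports. "The series", "measured", "known", "first", "only" and "open" are said of these compounds alone.

Compound 1 `CC(C)n1nc(-c2ccnc3[nH]c(C4CCN(CC(=O)N(C)C)CC4)cc23)ccc1=O` was examined in an ADME assay (Rattus norvegicus, strain Han-wistar) for metabolic stability, at a dose of 1.5 umol/kg by the intravenous route (on this read-out lower numbers stand for a shorter-lived compound and higher numbers for a longer-lived compound), and in that setting compound 1 gives 1 h. A second compound, compound 2 `COc1cc(C(=O)N2CCCC2)ccc1-c1ccnc2[nH]c(C3CCOCC3)cc12`, carries a different group on the shared core; in this assay compound 2 gives 0.5 h. Within the data shown here, of the two numbers recorded so far, the one for compound 1 is the larger, but its gap to compound 2 lies within the usual scatter of repeated measurements, so the two cannot be told apart on this read-out.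

Compound 3 `COc1cc(F)ccc1-c1ccnc2[nH]c(C3CCN(CC(=O)N(C)C)CC3)cc12` has not yet been measured in this assay. It differs from compound 1 in a single place: a group of 9 heavy atoms (7 carbon, 1 oxygen, 1 fluorine; one six-membered aromatic ring of carbon only) in place of a group of 10 heavy atoms (7 carbon, 2 nitrogen, 1 oxygen; one six-membered aromatic ring with 2 hetero atoms), on an aromatic carbon. No measured pair among these compounds shares that change, so there is no direct step to set its size. Because compound 1 gives 1 h and compound 2 gives 0.5 h, the step of a 1.4-fold lower number from compound 1 to compound 3 (0.15 log units; within the scatter) is expected to be small, leaning downward, and not beyond the scatter. Compound 3 is therefore estimated at 0.7 h, within a range from 0.35 h to 1.4 h.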

Compound 3, half-life in the Rattus norvegicus assay: 1 h
Estimate against measurement, compound 3: 1.4-fold (0.15 log units) below; the range from low to high includes it.
By their numbers in the Rattus norvegicus assay, from the lowest: compounds 2, 1 and 3 (each within the scatter of the next).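

At this aromatic carbon, opposite the ring nitrogen, the ring with hetero atoms of compound 1 can give way to the carbon-only 4-fluoro-2-methoxyphenyl of compound 3, and the Rattus norvegicus assay shows no change at the digits printed from compound 1 to compound 3 (within the scatter). In a physicochemical assay for acid dissociation, compound 1 gives 7.6 and compound 3 gives 8. The same change that leaves the half-life flat thus shifts acid dissociation, something the earlier compounds could not show: the measured acid dissociation constant of compound 1, 7.6, and of compound 3, 8, a number 0.40 log units higher (beyond the scatter)

The compounds shown leave open whether a pyridine ring or a phenyl ring bearing an amine at this carbon would also leave the half-life flat, and whether the fluorine or the methoxy group counts on its own, as the two enter together. Going by these compounds, with a single pair in hand, it also remains open whether half-life and acid dissociation have any link across the wider series.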